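Tail flick activity of ester analogues sharing one core

The source may hold more compounds than are shown below. What is called first, only, known or untested is meant among the compounds shown, and "the series" means these compounds.

Measured so far:
compound 1 `O=C(CN(c1ncnc2c1ncn2C1CCCCO1)C1CC1)N[C@@H](CO)C(=O)OCc1ccccc1` — 46.7%
compound 2 `NC(=O)C[C@H](NC(=O)CN(c1nc(Cl)nc2[nH]cnc12)C1CC1)C(=O)OCc1ccccc1` — 36.4%

In a functional assay on the whole organism (Tail, strain ICR) with Mus musculus as the target, in the tail flick test, with a stated time of 60 min, at a dose of 25 umol/kg by the oral route (a lower number here means a weaker effect, a higher number a stronger effect of the compound at the dose given), compound 1 stands highest of the two numbers. Among the compounds with values here, compound 2 gives a value that lies lower by an amount beyond the usual scatter; no step between these two is worked out here, so only the two values themselves are compared.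

Compound 3 `CC(C)(C)OC(=O)NCCCC[C@H](NC(=O)CN(c1ncnc2c1ncn2C1CCCCO1)C1CC1)C(=O)OCc1ccccc1` has not yet been measured in this assay. It differs from compound 1 in one place: 3-((tert-butoxycarbonyl)amino)propyl in place of hydroxy on a saturated chain carbon, two bonds along the chain from an amide-type nitrogen and a carbonyl carbon. Within the data shown here, no measured pair covers a change of this kind, so the expected size of the step rests on compound 1 alone and on the general spread seen in the two values.

The step is expected to be modest, with its direction uncertain, and it may amount to none beyond the scatter: a number 6.7 percentage points lower from compound 1 to compound 3 (within the scatter). Among the measured compounds shown here, compound 3 is therefore estimated at 40%, within a range from 18% to 62%, the wide range reflecting that nothing measured so far speaks to this particular change.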

Compound 3, a percentage reported as activity, at one dose (the size of the read-out at that dose, not a potency): 32.7%
For compound 3 the middle estimate is 7.3 percentage points above the measured one, within the range that was stated.
By their numbers in this assay, from the lowest: compounds 3 and 2 (each within the scatter of the next); then compound 1.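

In this assay this position, a saturated chain carbon two bonds along the chain from an amide-type nitrogen and a carbonyl carbon, now has its first measured step: 3-((tert-butoxycarbonyl)amino)propyl in place of hydroxy gives a number 14 percentage points lower from compound 1 to compound 3 (beyond the scatter) at the dose given. The read-out therefore responds to what this position carries, yet the change, with 11 heavy atoms entering for 1 leaving, does not abolish the effect, since compound 3 still gives 32.7% in this assay on the same core as compound 1. Nothing at hand accounts for the step, which stands as an observation without an assigned cause.

The compounds shown leave open whether the step belongs to the tert-butoxycarbonyl group or to the chain that carries it, a question that the free amine at the end of the same chain or a plain butyl chain without nitrogen would address. Also open, from the compounds shown here alone, is how a carboxylic acid or a shorter chain ending in hydroxy would read at this position, so no trend with chain length can be stated from this single step.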